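The compounds below may be only part of what the source reports. "The series", "measured", "known", "first", "only" and "open" are said of these compounds alone.

Three thioether-linked oximes of a shared design have been measured in a functional assay (blood) for inhibition, with Homo sapiens as the target; on this read-out higher numbers stand for weaker inhibition and lower numbers for stronger inhibition. Compound 1, `CO[C@]1(c2cnc(Sc3ccc(/C(C)=N/O)cc3)s2)CCO[C@@H](C)C1`, gives 40 nM. Compound 2, `COC1(c2csc(Sc3ccc4c(c3)CC/C4=N\OCC#N)c2)CCOCC1`, gives 40 nM, and compound 3, `COC1(c2csc(Sc3ccc4c(c3)CC/C4=N\O)c2)CCOCC1`, gives 130 nM. Compound 1 and compound 2 stand at the same number as far as the digits go, and that gap is within the scatter, so nothing separates them on this read-out. Compound 3 stands apart: the step of a 3.3-fold lower number from compound 3 to compound 2 (0.51 log units; beyond the scatter) is beyond the scatter. The change behind that step is cyanomethyl in place of hydrogen on an oxygen.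

The difference between the core of compound 1 and the core of compound 3 is not broken down here; the two differ in more than one place.

Compound 4, `CO[C@]1(c2cnc(Sc3ccc(/C(C)=N/OCC#N)cc3)s2)CCO[C@@H](C)C1`, has not yet been measured in this assay. It differs from compound 1 by cyanomethyl in place of hydrogen on an oxygen. The place of this change reads word for word as it does between compound 3 and compound 2, so it is the same change made on a different core.

For the measured compounds named here, because the one measured instance of this change, a 3.3-fold lower number from compound 3 to compound 2 (0.51 log units; beyond the scatter), lowered the number beyond the scatter, a step of similar direction is expected from compound 1 to compound 4, estimated at a 2.7-fold lower number from compound 1 to compound 4 (0.43 log units; beyond the scatter). That expectation rests on a single pair and on a core that is not the same, so it is held loosely. Compound 4 is accordingly estimated at 15 nM in this assay, with a range from 6 nM to 40 nM.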

Compound 4, half-maximal inhibitory concentration: 40 nM
Compound 4: the middle estimate sits 2.7-fold (0.43 log units) below what was measured; the range from low to high includes it.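

In this assay, the step on the core of compound 1 reads no change at the digits printed from compound 1 to compound 4 (within the scatter), so cyanomethyl in place of hydrogen on an oxygen does not lower the number here as it did on the other core. Set side by side, the two instances of this change do not agree: the same change on two cores in this assay, a 3.3-fold lower number (0.51 log units; beyond the scatter) from compound 3 to compound 2 and no change at the digits printed (within the scatter) from compound 1 to compound 4, 3.3-fold (0.51 log units) apart, beyond the scatter of two such steps This shows that, in this series, the size of the step measured on one core cannot simply be carried over to another, but two pairs do not show why the steps part ways, nor which of them is more typical of the change.

The two cores differ in more than one place, so the compounds shown leave open which of those differences goes with the loss of the step, and a pair of cores differing in only one place would be needed to tell. They also leave open how other groups on the same oxygen, such as methyl, a longer chain ending in a nitrile, or a chain ending in a carboxylic acid, would behave on each of the two cores.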